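The source may hold more compounds than are shown below. What is called first, only, known or untested is meant among the compounds shown, and "the series" means these compounds.

Compound 1 `Cc1ccc(-n2cc(CNC(=O)c3cccc4c3cnn4C(C)C)nn2)cc1C` and compound 2 `CC(C)n1ncc2c(C(=O)NCc3cn(-c4cccc(Br)c4)nn3)cccc21` share the same core and differ only in the group carried on an aromatic nitrogen. In a functional assay on MGC-803 cells (Homo sapiens) for inhibition, read by MTT assay, with a stated time of 72 h (a higher number here means a weaker inhibitor, a lower number a stronger inhibitor), compound 1 reaches only the limit of the measurement, > 40000 nM. In this assay compound 2 likewise reaches only the limit, > 40000 nM. The step that the two limits leave unreadable from compound 1 to compound 2 therefore cannot be read, since both of its ends sit at the limit of > 40000 nM in this assay, at which 2 of the 2 values shown sit. Compound 3 `CC(C)n1ncc2c(C(=O)NCc3cn(-c4cccc(F)c4)nn3)cccc21` has not yet been measured. It differs from compound 2 by fluoro in place of bromo on an aromatic carbon. For the measured compounds named here, no measured step concerns a fluoro for bromo exchange, and the single measured step, which comes from a change on the same ring, is itself unreadable. Going by the values given here, with compound 2 sitting at the limit, and no step anywhere showing a gain, the expected step that the limit leaves unreadable from compound 2 to compound 3 is small, and the number for compound 3 is expected most likely to be reported once more only as a limit. In this assay compound 3 is therefore estimated at 60000 nM, with a range from 20000 nM to 200000 nM.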

Compound 3, half-maximal inhibitory concentration: > 40000 nM
Compound 3: no number, only a limit (the forecaster's own chance of this, stated with the estimate: 80%); the middle value is on the limit's open side.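

The steps from compound 2 to compound 3 and from compound 1 to compound 3 cannot be read, because neither end of either step is a number, only a limit: the limit of > 40000 nM in this assay, at which 3 of the 3 values shown sit.

Compound 1, compound 2 and compound 3 leave open how strongly each actually inhibits in this assay, and whether any change to the group on the shared core would give a readable value.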